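Methoxy for methyl on a benzoxazole sulfonamide

The compounds below may be only part of what the source reports. "The series", "measured", "known", "first", "only" and "open" are said of these compounds alone.

Measured compounds:
compound 1, `O=S(=O)(Nc1ccc(-c2nc3ccccc3o2)cc1)c1ccccc1C(F)(F)F`, 74000 nM
compound 2, `Cc1cccc(S(=O)(=O)Nc2ccc(-c3nc4ccccc4o3)cc2)c1`, > 100000 nM
compound 3, `O=S(=O)(Nc1ccc2oc(-c3ccccc3)nc2c1)c1ccc(O)cc1`, 88000 nM

In an assay on cells for inhibition of HSP60/HSP10 (Homo sapiens), with a stated time of 60 min (on this read-out higher numbers stand for weaker inhibition and lower numbers for stronger inhibition), compound 1 gives 74000 nM. In this assay compound 3 gives 88000 nM. Within the data shown here, for compound 2 the result is only a limit of the assay, > 100000 nM, the point at which one of the three values sits (the limit of > 100000 nM in this assay, at which 1 of the 3 values shown sits); no number is known for it, and so no measured step can be drawn from it. Compound 4, `COc1cccc(S(=O)(=O)Nc2ccc(-c3nc4ccccc4o3)cc2)c1`, is not yet measured. It differs from compound 2 by methoxy in place of methyl on an aromatic carbon. Given that compound 2 sits at a limit, the step from compound 2 to compound 4 is expected to be small, a number no higher from compound 2 to compound 4 (the limit leaves the size open), with no direction beyond the scatter. Compound 4 is estimated at 100000 nM, between 40000 nM and 250000 nM.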

Compound 4, half-maximal inhibitory concentration: 80000 nM
Estimate against measurement, compound 4: 1.3-fold (0.10 log units) above; measured number inside the range.
By their numbers in this assay, from the lowest: compounds 1, 4 and 3 (each within the scatter of the next). At a limit, above all of these: compound 2.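

With methoxy in place of methyl on an aromatic carbon, this assay shows an at least 1.2-fold lower number from compound 2 to compound 4 (0.09 log units; that floor lies within the scatter). Compound 4 gives a number at this place, meta to a large group, where compound 2 gives only a limit of the assay. The true size of the step therefore stays unknown, and it may be larger than this floor: the limit of > 100000 nM in this assay, at which 1 of the 4 values shown sits.

On these data alone, whether an amine or a carboxylic acid at this place would move the number beyond the scatter remains open. The compounds shown also leave open whether any change here gives a clear step.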